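Swapping the aryl group on the carbonyl of compound 3

The compounds below may be only part of what the source reports. "The series", "measured", "known", "first", "only" and "open" are said of these compounds alone.

In a functional assay on SR cells (Homo sapiens) for cytotoxicity, read by sulforhodamine B assay, with a stated time of 48 h, tested at 10 uM (on this read-out higher numbers stand for a weaker effect at the one concentration tested and lower numbers for a stronger effect), compound 3 `COc1ccc(C(=O)/C=C/c2cc(-c3cc(OC)c(OC)c(OC)c3)n[nH]2)cc1` gives 3%, the highest of the three numbers shown. Compound 2 `COc1ccc(C(=O)/C=C/c2cc(-c3cc(OC)c(OC)c(OC)c3)n[nH]2)cc1OC` gives 2%, and the step of a number 1 percentage points higher from compound 2 to compound 3 (within the scatter) stays within the scatter. Compound 1 `COc1cc(-c2cc(/C=C/C(=O)c3ccc(N)cc3)[nH]n2)cc(OC)c1OC` gives -18%; the steps of a number 20 percentage points higher from compound 1 to compound 2 (beyond the scatter) and a number 21 percentage points higher from compound 1 to compound 3 (beyond the scatter) are both modest and beyond the scatter, showing that the group on the carbonyl carbon can move the read-out. Compound 4 `COc1cc(-c2cc(/C=C/C(=O)c3ccc(F)c(F)c3)[nH]n2)cc(OC)c1OC` differs from compound 3 by 3,4-difluorophenyl in place of 4-methoxyphenyl on a carbonyl carbon. Among the compounds with values here, no measured step shows this exact change, so the expected step of a number 3 percentage points lower from compound 3 to compound 4 (within the scatter) is small and uncertain in direction. Compound 4 is therefore estimated at 0% in this assay, with a range from -25% to 20%.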

Compound 4, a percentage reported as activity, at one concentration (the size of the read-out at that concentration, not a potency): 11%
Compound 4: the middle estimate sits 11 percentage points below what was measured; low and high end bracket the measured number.
By their numbers in this assay, from the lowest: compound 1; then compounds 2, 3 and 4 (each within the scatter of the next).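

Placing 3,4-difluorophenyl on the carbonyl carbon, a group with no hydrogen-bond acceptor, gives a read-out that cannot be told apart from those of the methoxy-bearing groups: the result is a number 8 percentage points higher from compound 3 to compound 4 (within the scatter) and a number 9 percentage points higher from compound 2 to compound 4 (within the scatter). Among the groups shown, only 4-aminophenyl stands apart, with a number 29 percentage points higher from compound 1 to compound 4 (beyond the scatter). Nothing available explains this difference. The compounds shown leave open whether the separation of compound 1 is particular to the amine or also holds for other groups on the phenyl ring, such as a dimethylamino group, an acetamide or a carboxylic acid.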